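A few compounds are considered here, and "the series" means these few. Any claim that something is new, unique, unknown or untested is made for them only; others in the source may bear on it.

Measured so far in an ADME assay on WI-38 cells (Homo sapiens) for inhibition, read by CellTiter-Glo, with a stated time of 48 h, tested at 100 uM; a higher number here means more inhibition at the concentration tested (going by the name of the read-out), a lower number less inhibition:
compound 1 `CCOC(=O)/C=C/NC(=O)[C@H](O)C(C)(C)CO`: 36%
compound 2 `CC(C)(C)OC(=O)/C=C\NC(=O)[C@H](O)C(C)(C)CO`: -14%
compound 3 `CC(C)(CO)[C@@H](O)C(=O)N/C=C\C(=O)OCc1ccccc1`: 4%

Compound 3 stands second highest of the three in this assay, above compound 2 and well below compound 1. The next compound, compound 4 `CCOC(=O)/C=C\NC(=O)[C@H](O)C(C)(C)CO`, differs from compound 3 in one place: methyl in place of phenyl on a saturated chain carbon bound to an oxygen next to a carbonyl group. For the measured compounds named here, the one measured step on the same oxygen next to a carbonyl group is a number 18 percentage points higher from compound 2 to compound 3 (beyond the scatter), so swapping groups at this position moves the read-out modestly. Going by the values given here, compound 1 also carries an ethyl here and gives 36%, though it differs from compound 4 in another place, so no step is given for that pair. A small upward step, a number 8 percentage points higher from compound 3 to compound 4 (within the scatter), is expected. Compound 4 is estimated at 12%, between -12% and 36%.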

Compound 4, a percentage reported as inhibition, at one concentration (the size of the read-out at that concentration, not a potency): 1%
Beside the measured number, compound 4's estimate is 11 percentage points above it; low and high end bracket the measured number.
By their numbers in this assay, from the lowest: compound 2; then compounds 4 and 3 (each within the scatter of the next); then compound 1.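

In this assay, the swap from benzyl to ethyl on the Z-drawn double bond leaves the read-out without a real shift (a number 3 percentage points lower from compound 3 to compound 4 (within the scatter)), while ethyl in place of tert-butyl gives a modest change (a number 15 percentage points higher from compound 2 to compound 4 (beyond the scatter)). The largest change shown does not involve the ester group at all (a number 35 percentage points lower from compound 1 to compound 4 (beyond the scatter)), and it can be assigned to the double bond as drawn: the fact that compounds 1 and 4 differ only in the configuration as drawn.

Still open, going by these compounds, is whether the E double bond gives a similar gap with benzyl or tert-butyl on the oxygen. On these data alone, how a carboxylic acid or a longer chain there would read is also open.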